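Shrinking the Ring: Oxolane to Oxetane

This account rests on a few compounds, and the source may have more. Where it says the series, first, only, none or still open, it means among the compounds named here.

Compound 1 `CC1(C)CO[C@@H]1CN([C@H](CCC(F)(F)F)C(N)=O)S(=O)(=O)c1ccc(Cl)cc1`: > 293 mL/min/kg
Compound 2 `NC(=O)[C@@H](CCC(F)(F)F)N(C[C@@H]1COCCO1)S(=O)(=O)c1ccc(Cl)cc1`: 117 mL/min/kg
Compound 3 `NC(=O)[C@@H](CCC(F)(F)F)N(C[C@H]1CCOC1)S(=O)(=O)c1ccc(Cl)cc1`: 83.4 mL/min/kg

All three were run in an in vitro ADME assay on microsomes from liver (Homo sapiens) for metabolic stability, read by HPLC; a lower number here means slower removal, a higher number faster removal of the compound. For compound 1 the reading is a limit of the assay rather than a number (the limit of > 293 mL/min/kg in this assay, at which 1 of the 3 values shown sits). Compound 3 and compound 2 sit close together, since a 1.4-fold lower number from compound 2 to compound 3 (0.15 log units; within the scatter), so on the two numbers shown compound 3 holds no separate place of its own. The only clear movement is an at least 3.5-fold lower number from compound 1 to compound 3 (0.54 log units; beyond the scatter), and likewise an at least 2.5-fold lower number from compound 1 to compound 2 (0.39 log units; beyond the scatter).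

Compound 4 `NC(=O)[C@@H](CCC(F)(F)F)N(C[C@@H]1CCO1)S(=O)(=O)c1ccc(Cl)cc1` differs from compound 3 in one place: oxetan-2-yl in place of oxolan-3-yl on a saturated chain carbon bound to a sulfonamide nitrogen. This returns to a four-membered ring like that of compound 1, but without its two methyl groups. Because the step of an at least 3.5-fold lower number from compound 1 to compound 3 (0.54 log units; beyond the scatter) was at least modest, part of that gap is expected to reopen, though the missing methyl groups leave the size uncertain. The expected step is a 1.8-fold higher number from compound 3 to compound 4 (0.25 log units; within the scatter). For compound 4 the estimate in this assay is 150 mL/min/kg, with a range from 70 mL/min/kg to 300 mL/min/kg.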

Compound 4, clearance: 62.1 mL/min/kg
The estimate for compound 4 lay 2.4-fold (0.38 log units) above the measured number; the whole stated range lies above it.
By their numbers in this assay, from the lowest: compounds 4, 3 and 2 (each within the scatter of the next). At a limit, above all of these: compound 1.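

Swapping 3,3-dimethyloxetan-2-yl for oxetan-2-yl on this saturated chain carbon bound to a sulfonamide nitrogen gives an at least 4.7-fold lower number from compound 1 to compound 4 (0.67 log units; beyond the scatter) in this assay, so a four-membered ring alone does not place a compound at the top of this scale. The rings of different size now cannot be told apart here, with a 1.3-fold lower number from compound 3 to compound 4 (0.13 log units; within the scatter) and a 1.9-fold lower number from compound 2 to compound 4 (0.28 log units; within the scatter). Compound 1 remains the one compound read as a limit rather than a number: the limit of > 293 mL/min/kg in this assay, at which 1 of the 4 values shown sits.

Going by these compounds alone, whether the single methyl groups on oxetan-2-yl would already move the number, and how large the true gap to compound 1 is, stays open. So does whether an amine ring such as azetidin-2-yl, or an open ether chain such as 2-methoxyethyl, would stay with compounds 2, 3 and 4.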